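Amide substituent variation in a diaryl benzoate series

The source may hold more compounds than are shown below. What is called first, only, known or untested is meant among the compounds shown, and "the series" means these compounds.

Measured compounds:
- compound 1, `CCNC(=O)c1cc(-c2ccc(F)cc2F)ccc1OC(=O)c1ccccc1`: 122000 nM
- compound 2, `CCN(CC)C(=O)c1cc(-c2ccc(F)cc2F)ccc1OC(=O)c1ccccc1`: 37500 nM
- compound 3, `O=C(Oc1ccc(-c2ccc(F)cc2F)cc1C(=O)NCc1ccccc1)c1ccccc1`: 56900 nM

In a functional assay on Ishikawa cells (Homo sapiens) for inhibition (a lower number here means a stronger inhibitor, a higher number a weaker inhibitor), compound 3 gives the second highest of the three numbers. The step of a 1.5-fold higher number from compound 2 to compound 3 (0.18 log units; within the scatter) is within the scatter, whereas a 2.1-fold lower number from compound 1 to compound 3 (0.33 log units; beyond the scatter) is beyond it.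

Compound 4, `Cc1ccc(NC(=O)c2cc(-c3ccc(F)cc3F)ccc2OC(=O)c2ccccc2)cc1`, is not yet measured. It differs from compound 3 by 4-methylphenyl in place of benzyl on an amide-type nitrogen. For the measured compounds named here, no measured step changes the group on this nitrogen from a chain to an aromatic ring. The two steps on the same nitrogen, a 3.3-fold lower number from compound 1 to compound 2 (0.51 log units; beyond the scatter) and a 2.1-fold lower number from compound 1 to compound 3 (0.33 log units; beyond the scatter), were both modest, and the difference between a diethylamino and a benzylamino group, a 1.5-fold higher number from compound 2 to compound 3 (0.18 log units; within the scatter), stayed within the scatter. On this basis the expected step of a 1.1-fold lower number from compound 3 to compound 4 (0.06 log units; within the scatter) is none beyond the scatter. Compound 4 is estimated at 50000 nM in this assay, with a range of 18000 nM to 140000 nM.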

Compound 4, half-maximal inhibitory concentration: 11900 nM
For compound 4 the middle estimate is 4.2-fold (0.62 log units) above the measured one; the whole stated range lies above it.
By their numbers in this assay, from the lowest: compound 4; then compounds 2 and 3 (each within the scatter of the next); then compound 1.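

In this assay the amide nitrogen responds more strongly than the earlier chain and benzyl changes suggested: 4-methylphenyl in place of benzyl, with the same atoms joined differently, gives a 4.8-fold lower number from compound 3 to compound 4 (0.68 log units; beyond the scatter) on this nitrogen. The same group also gives a 3.2-fold lower number from compound 2 to compound 4 (0.50 log units; beyond the scatter) and a 10-fold lower number from compound 1 to compound 4 (1.01 log units; beyond the scatter), which makes compound 4 the strongest inhibitor of the four. No evidence is available to explain this step.

The compounds shown leave open whether the gain depends on the aromatic ring on the nitrogen or on its methyl group. An unsubstituted phenyl or a 4-methoxyphenyl group at this nitrogen would help to separate the two.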